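This account rests on a few compounds, and the source may have more. Where it says the series, first, only, none or still open, it means among the compounds named here.

Measured so far:
compound 1 `N#CC1CN1C(=O)Nc1ccc(Cl)c(Cl)c1`: 5900 nM
compound 2 `N#CC1CN1C(=O)Nc1ccc(S(N)(=O)=O)cc1`: 188000 nM

Both numbers come from a functional assay on A-375 cells (Homo sapiens) for inhibition; on this read-out lower numbers stand for stronger inhibition and higher numbers for weaker inhibition. Going by the values given here, compound 2 stands at the highest of the two numbers; the only other compound, compound 1, sits far lower, and the gap between the two is well beyond the usual scatter of repeated measurement. Compound 2 thus marks the weak end of this small series as it stands.

The next compound, compound 3 `N#CC1CN1C(=O)Nc1ccccc1`, is not yet measured. It differs from compound 2 in one place: hydrogen in place of sulfamoyl on an aromatic carbon. The sulfamoyl leaves and hydrogen enters on an aromatic carbon of a six-membered aromatic ring of carbon only; the shared core is untouched.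

Among the compounds with values here, no step between measured compounds is known, so the size of this one can only be guessed. Compound 1 at 5900 nM shows how much lower the shared core can reach with other substitution on that ring. The step from compound 2 to compound 3 is expected to lower the number beyond the scatter, estimated at a 4.7-fold lower number from compound 2 to compound 3 (0.67 log units; beyond the scatter). Compound 3 is therefore estimated at 40000 nM, in the range 10000 nM to 150000 nM. Only the measurement will tell.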

Compound 3, half-maximal inhibitory concentration: 11000 nM
The estimate for compound 3 lay 3.6-fold (0.56 log units) above the measured number; low and high end bracket the measured number.
By their numbers in this assay, from the lowest: compounds 1 and 3 (each within the scatter of the next); then compound 2.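

Hydrogen in place of sulfamoyl on an aromatic carbon, para to a group of 8 heavy atoms, gives a 17-fold lower number from compound 2 to compound 3 (1.23 log units; beyond the scatter) in this assay, a large step and the first single-place change that can be read in this series. The high number of compound 2 therefore goes with the sulfamoyl group at this position, since compound 3 reaches 11000 nM with no heavy atom there at all. No measured property of either group bears on this step, and the size of the step remains without an explanation.

This single pair cannot show whether sulfamoyl is unusual at this carbon or whether any larger group there would raise the number, so a methoxy group, an amine, a carboxylic acid or a single chlorine on the same carbon would each need to be read against compound 3. The compounds shown also leave open how the other carbons of the ring respond when each is changed on its own, as no single-place step from compound 3 to a substituted partner other than compound 2 is available.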